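The source may report more compounds than this note shows. Statements on the series, on what has been measured and on what is new or still open speak of the compounds shown alone.

For the measured compounds named here, in an in vivo ADME assay on the whole organism for pharmacokinetics, with Rattus norvegicus as the target (a lower number here means that a smaller share of the oral dose reaches the circulation, a higher number that a larger share of the oral dose reaches the circulation), compound 1 `O=C(NC1CCCCC1)N1CCN(c2nc(-c3ccc4ccccc4n3)no2)CC1` gives 24% and holds the lower of the two numbers so far. Compound 2 `Cn1c(-c2noc(C3CCN(C(=O)NC4CCCCC4)CC3)n2)nc2ccccc21` gives 59% in this assay and stands above compound 1 by a gap beyond the scatter. The next compound to be read is compound 3 `Cn1c(-c2noc(N3CCN(C(=O)NC4CCCCC4)CC3)n2)nc2ccccc21` which keeps compound 1 except for one group. The change is 1-methyl-1H-benzimidazol-2-yl in place of quinolin-2-yl on an aromatic carbon and the group sits on the five-membered aromatic ring with 2 nitrogen and 1 oxygen, between two ring nitrogen atoms. Going by the values given here, the series holds no measured step for this exchange. Among the compounds with values here, the only pointer is compound 2 at 59% which also carries the 1-methyl-1H-benzimidazol-2-yl group. Compound 2 also differs from compound 1 elsewhere, so the whole gap is not expected to carry over. The expected direction is upward, an estimated a number 16 percentage points higher from compound 1 to compound 3 (beyond the scatter) that may or may not clear the scatter. In this assay the expected value for compound 3 is 40% with a range from 25% to 58% as estimated here.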

Compound 3, oral bioavailability: 10%
The estimate for compound 3 lay 30 percentage points above the measured number; the measured number lies below the stated range.
By their numbers in this assay, from the lowest: compound 3; then compound 1; then compound 2.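

On an aromatic carbon of the five-membered ring, between two ring nitrogen atoms, the exchange of quinolin-2-yl for 1-methyl-1H-benzimidazol-2-yl is not neutral in this assay: the step is a number 14 percentage points lower from compound 1 to compound 3 (beyond the scatter), even though both groups have 10 heavy atoms and the count of hydrogen-bond acceptors only goes from 1 to 2. The 1-methyl-1H-benzimidazol-2-yl group therefore does not go with a high number on its own, since compound 2 carries it at 59% and compound 3 carries it at 10%, with the two compounds differing in one place in the core. Nothing at hand accounts for the step or for that difference between compound 2 and compound 3.

The compounds shown leave open whether the step keeps its direction on the core of compound 2, as no quinolin-2-yl partner on that core is among them. Going by these compounds, it is also open how this position responds to a simpler group, such as phenyl or an unmethylated 1H-benzimidazol-2-yl, which would show whether the N-methyl group or the ring system goes with the lower number.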